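Alkyl size change on the shared core, lipophilicity outlook

The compounds below may be only part of what the source reports. "The series", "measured", "known", "first", "only" and "open" are said of these compounds alone.

Three measured compounds share a fused core. Compound 1 `O=c1oc(NC2CCCCC2)nc2ccccc12` in a physicochemical assay for lipophilicity (on this read-out higher numbers stand for higher lipophilicity and lower numbers for lower lipophilicity), gives 3.5. Compound 2 `CCOc1nc2cc(N)cc(CC)c2c(=O)o1` in this assay gives 2.7. Compound 3 `Cc1nc2c(C)cccc2c(=O)o1` in this assay gives 2.1, the lowest of the three numbers: compound 2 is the nearest, with a value beyond the scatter from compound 3, and compound 1 is the furthest, also beyond the scatter. Going by the values given here, no two of these three compounds differ in a single place, so no single step between measured compounds can be read off; the pairs show only what their two values are.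

Compound 4 `Cc1cccc2c(=O)oc(C(C)(C)C)nc12` is not yet measured. Its change from compound 3 is tert-butyl in place of methyl on an aromatic carbon. Among the compounds with values here, nothing among the measured compounds isolates this kind of change, so the expectation rests on the change itself, a larger alkyl group entering in place of methyl, with no change in rings, donors, acceptors or charge. The step from compound 3 to compound 4 in this assay is expected to be upward and beyond the scatter, at about a number 1.30 log units higher from compound 3 to compound 4 (beyond the scatter). Compound 4 is estimated at 3.4 in this assay, with a range from 2.9 to 3.9.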

Compound 4, distribution coefficient: 4
Estimate against measurement, compound 4: 0.60 log units below, and the stated range ends below it.
By their numbers in this assay, from the lowest: compound 3; then compound 2; then compound 1; then compound 4.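

In this assay, going by these compounds alone, tert-butyl in place of methyl on an aromatic carbon gives a number 1.90 log units higher from compound 3 to compound 4 (beyond the scatter) and this is the only step that isolates a change at one place. Within the data shown here, compound 4 gives the first direct reading for this position, the aromatic carbon next to the ring nitrogen and next to the ring oxygen: the read-out moves upward when the alkyl group grows from 1 heavy atom to 4, while the counts of rings, hydrogen-bond donors, hydrogen-bond acceptors and net charge stay the same. Nothing presented here accounts for the size of this step.

As far as these compounds go, because the series offers just this one step, it remains open whether the read-out climbs evenly through intermediate groups such as ethyl or isopropyl, or whether a longer chain such as n-butyl gives a step of similar size. From the compounds shown here alone, it is equally open how a group of another kind at this carbon, such as a primary amine or a carboxylic acid, would read, and whether the same tert-butyl change gives a comparable step on the other substitution patterns of the shared core.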